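This account rests on a few compounds, and the source may have more. Where it says the series, first, only, none or still open, it means among the compounds named here.

Measured compounds:
compound 1 `O=C(CSc1nc(Nc2ccccc2)c2ccccc2n1)Nc1cccc([N+](=O)[O-])c1` — in a functional assay on PC-3 cells (Homo sapiens) for inhibition, read by MTT assay, with a stated time of 72 h (on this read-out lower numbers stand for stronger inhibition and higher numbers for weaker inhibition), compound 1 gives 11800 nM
compound 2 `C=CC(=O)Nc1cccc(NC(=O)CSc2nc(Nc3cccc(F)c3)c3ccccc3n2)c1` — in this assay compound 2 gives 5370 nM

Of the two numbers shown, compound 2 has the lower one; compound 1 lies higher by a gap that is beyond the usual scatter, so compound 2 is the stronger of the pair on this read-out. The two also differ in more than one place, so their values show only this ordering and nothing about any single change.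

Compound 3 `C=CC(=O)Nc1cccc(NC(=O)CSc2nc(Nc3cc(OC)c(OC)c(OC)c3)c3ccccc3n2)c1` has not yet been measured. It differs from compound 2 in one place: 3,4,5-trimethoxyphenyl in place of 3-fluorophenyl on a nitrogen on an aromatic ring. Among the measured compounds shown here, no measured pair shows what this change does, so the expected step from compound 2 to compound 3 in this assay is small, with no clear direction, and is estimated at a 1.2-fold lower number from compound 2 to compound 3 (0.08 log units; within the scatter). On that basis compound 3 is expected to give about 4500 nM in this assay, with a plausible range from 1500 nM to 14000 nM.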

Compound 3, half-maximal inhibitory concentration: > 50000 nM
Compound 3 was reported as a limit; the forecaster's own chance of this, stated with the estimate: 8%; middle value at least 11-fold (1.04 log units) from the limit.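

In this assay, the group on this nitrogen proves to matter: 3,4,5-trimethoxyphenyl in place of 3-fluorophenyl gives an at least 9.3-fold higher number from compound 2 to compound 3 (0.96 log units; beyond the scatter). Among the compounds shown here, this is the first comparison at this position that changes only one place, which compound 1 and compound 2, differing in more than one place, could not provide. Compound 3 gives > 50000 nM, which is a limit of the assay and not a number, so the step marks only a bound and its full size stays unknown: the limit of > 50000 nM in this assay, at which 1 of the 3 values shown sits.

As far as these compounds go, whether the loss of inhibition needs all three methoxy groups or would already appear with a single methoxy group remains open. Also open, from the compounds shown here alone, is how this position would respond to an amine or a carboxylic acid on the phenyl ring.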